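Methoxyphenyl in place of fluorodimethylphenyl on the cinnamamide

The source may hold more compounds than are shown below. What is called first, only, known or untested is meant among the compounds shown, and "the series" means these compounds.

Measured compounds:
- compound 1 `Cc1cc(/C=C/C(=O)NCCn2c(C(F)(F)F)cc3ccccc32)cc(C)c1F`: 306 nM
- compound 2 `COc1cc(/C=C/C(=O)NCCN2CCCCC2C)cc(OC)c1OC`: a limit of the assay, > 1000 nM
- compound 3 `COc1cc(/C=C/C(=O)NCCn2c(C)c(CN(C)C)c3ccccc32)cc(OC)c1OC`: a limit of the assay, > 1000 nM

Among the compounds with values here, in an assay on C6 cells for antagonist activity at prostaglandin E2 receptor EP2 subtype (Homo sapiens), read by TR-FRET, with stated times of 10 min and 40 min, tested at 1 uM (a lower number here means a stronger inhibitor, a higher number a weaker inhibitor), compound 1 is the only compound with a number; the other two sit at the limit of > 1000 nM in this assay, at which 2 of the 3 values shown sit. Compound 4 `COc1ccc(/C=C/C(=O)NCCn2c(C(F)(F)F)cc3ccccc32)cc1` has not been measured. It differs from compound 1 by 4-methoxyphenyl in place of 4-fluoro-3,5-dimethylphenyl on a double-bonded chain carbon bound to a double-bonded chain carbon. Within the data shown here, compounds 2 and 3 carry methoxy groups on their aryl ring and both reach only a limit, but they differ from compound 1 in other places as well, so no step can be measured. For compound 4 the step from compound 1 is expected to weaken inhibition, a 2.3-fold higher number from compound 1 to compound 4 (0.36 log units; beyond the scatter). Compound 4 is thus estimated at 700 nM, between 250 nM and 2000 nM.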

Compound 4, antagonist equilibrium constant: 305 nM
The estimate for compound 4 lay 2.3-fold (0.36 log units) above the measured number, within the range that was stated.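

In this assay the 4-methoxyphenyl and 4-fluoro-3,5-dimethylphenyl groups cannot be told apart at this place on the chain (a 1.0-fold lower number from compound 1 to compound 4 (0.00 log units; within the scatter)). Within the data shown here, this is the first step that can be read here, and it shows that a methoxy group on this aryl ring does not by itself bring a compound to the limit of the assay, a question compounds 2 and 3 left unsettled. Nothing measured here accounts for this match. On these data alone, what a 4-aminophenyl or 4-carboxyphenyl group would give at this place remains open, as does the effect of a longer chain.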